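The source may hold more compounds than are shown below. What is called first, only, known or untested is meant among the compounds shown, and "the series" means these compounds.

Compound 1 `ClCc1ccccc1Cn1cnc2c(Cl)nc(Cl)nc21`: in a functional assay on NCI/ADR-RES cells (Homo sapiens) for cytotoxicity, read by sulforhodamine B assay, with a stated time of 48 h (a higher number here means a weaker inhibitor of growth, a lower number a stronger inhibitor of growth), compound 1 gives 3020 nM.
Compound 2 `ClCc1ccccc1Cn1cnc2c(Cl)ncnc21`: compound 2 gives 4670 nM.
Compound 3 `ClCc1ccc(Cn2cnc3c(Cl)nc(Cl)nc32)cc1`: compound 3 gives > 100000 nM, which is a limit of this assay and not a number (the limit of > 100000 nM in this assay, at which 1 of the 3 values shown sits).

Going by the values given here, compound 2 thus holds the higher of the two numbers that were obtained, its nearest neighbour being compound 1, and the one measured step, a 1.5-fold higher number from compound 1 to compound 2 (0.19 log units; within the scatter), stays within the scatter. Compound 4 `Nc1nc(Cl)c2ncn(Cc3ccccc3CCl)c2n1` differs from compound 2 by amino in place of hydrogen on an aromatic carbon. Among the compounds with values here, no measured step introduces an amino group, so the only guide is that chloro-for-hydrogen exchange, which moved little. Compound 4 is therefore expected to give about 4500 nM, with a range from 1500 nM to 14000 nM. That estimate corresponds to a step of a 1.0-fold lower number from compound 2 to compound 4 (0.02 log units; within the scatter), expected to remain within the scatter.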

Compound 4, concentration for total growth inhibition: 34700 nM
Estimate against measurement, compound 4: 7.7-fold (0.89 log units) below, and the stated range ends below it.
By their numbers in this assay, from the lowest: compounds 1 and 2 (each within the scatter of the next); then compound 4. At a limit, above all of these: compound 3.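

The carbon between two ring nitrogen atoms is not indifferent to its substituent in this assay. Hydrogen and chloro there gave values within the scatter of each other, whereas amino produced a 7.4-fold higher number from compound 2 to compound 4 (0.87 log units; beyond the scatter) and, measured against chloro, an 11-fold higher number from compound 1 to compound 4 (1.06 log units; beyond the scatter). Going by these compounds alone, this is the first change at this position that moves the number beyond the scatter, and it weakens growth inhibition.

Nothing shown here accounts for this loss. As far as these compounds go, whether a methoxy or dimethylamino group on this carbon would match compound 4 or instead compound 1 and compound 2 remains open.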